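This account rests on a few compounds, and the source may have more. Where it says the series, first, only, none or still open, it means among the compounds named here.

Measured compounds:
- compound 1 `COc1cc(/C=C/C(=O)c2sc(Nc3ccccc3C)nc2C)cc(OC)c1OC` — 6320 nM in a functional assay on NCI-H460 cells (Homo sapiens) for cytotoxicity, read by MTT assay; a lower number here means a stronger inhibitor, a higher number a weaker inhibitor
- compound 2 `COc1cccc(/C=C/C(=O)c2sc(Nc3cccc(Cl)c3)nc2C)c1` — > 25000 nM, a limit of this assay
- compound 3 `Cc1ccccc1Nc1nc(C)c(C(=O)/C=C/c2ccccc2)s1` — > 25000 nM, a limit of this assay

Compound 1 stands alone on the numbers shown: it is the only one of the three to give a value in this assay, at 6320 nM. Compound 2 reaches only a limit, > 25000 nM. Compound 3 likewise gives only a limit, > 25000 nM. Among the compounds with values here, that two of the three results sit at the limit of > 25000 nM in this assay, at which 2 of the 3 values shown sit, is the whole of the evidence around compound 1, and no step between measured compounds can be read from it.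

The new compound is compound 4 `COc1cc(/C=C/C(=O)c2sc(Nc3ccc(Cl)cc3)nc2C)cc(OC)c1OC`, which keeps the core of compound 1 and changes one group on the nitrogen on an aromatic ring: 4-chlorophenyl in place of 2-methylphenyl on a nitrogen on an aromatic ring. Compound 3 carries the same 2-methylphenyl as compound 1 and yet sits at its limit, while compound 2 carries a chlorophenyl and also sits at its limit, so neither group by itself is tied to a number here.

Compound 4 is expected to stay close to compound 1, with a step of a 1.4-fold higher number from compound 1 to compound 4 (0.15 log units; within the scatter) in this assay, no larger than the scatter. The estimate for compound 4 is 9000 nM, within a range from 3000 nM to 25000 nM.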

Compound 4, half-maximal inhibitory concentration: 22000 nM
Compound 4: middle estimate off by 2.4-fold (0.39 log units), on the low side; measured number inside the range.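

In this assay, replacing 2-methylphenyl with 4-chlorophenyl on the nitrogen on an aromatic ring, with the core of compound 1 otherwise kept, gives a 3.5-fold higher number from compound 1 to compound 4 (0.54 log units; beyond the scatter), a modest step beyond the scatter and the first that can be read in this set. This shows that the group at this position changes the number, and that of these two groups, the 2-methylphenyl goes with the lower number and so the stronger result. Compound 4 still gives a measured number, 22000 nM. Compound 2 and compound 3 give no such number: the limit of > 25000 nM in this assay, at which 2 of the 4 values shown sit.

The compounds shown do not tell whether the step follows the chlorine or its place on the ring, as the two change together, and a 2-chlorophenyl, a 4-methylphenyl or an unsubstituted phenyl on the same nitrogen would help to separate them. Within the data shown here, compound 2 and compound 3 give only limits, so no steps to them can be read, and whether a group such as 4-aminophenyl or 4-methoxyphenyl at this position would give a lower number than compound 1 stays open.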